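Series notes: aryl oxazole amides and a cyclobutyl variant

This account rests on a few compounds, and the source may have more. Where it says the series, first, only, none or still open, it means among the compounds named here.

Measured compounds:
compound 1 `CCn1cccc(-c2ccc(N3C[C@H](CNC(=O)c4ccc(Cl)s4)OC3=O)cc2OC)c1=O` 61 nM
compound 2 `CCCN(CC1CCOC1)C(=O)c1cc(CC)c2oc(NCc3cccc(Cl)c3)nc2c1` 104 nM
compound 3 `COc1cc(C(=O)N2CCC(O)C(C)C2)cc2nc(NCc3cc(Cl)ccn3)oc12` 190 nM

In an assay on isolated protein for inhibition of thyroid hormone receptor beta (Homo sapiens), read by fluorescence, with a stated time of 30 min (a higher number here means a weaker inhibitor, a lower number a stronger inhibitor), compound 3 gives the highest of the three numbers. Compound 2 sits closest to it, within the scatter, so no order between the two can be read; compound 1 lies furthest, with a gap beyond the scatter. Compound 4 `COc1cc(C(=O)N2CCC(O)C(C)C2)cc2nc(NC3(c4cccc(Cl)c4)CCC3)oc12` differs from compound 3 in one place: 1-(3-chlorophenyl)cyclobutyl in place of (4-chloropyridin-2-yl)methyl on a nitrogen on an aromatic ring. Among the measured compounds shown here, no step between measured compounds isolates this change. Compound 2, carrying a chlorophenyl unit on the same nitrogen, sits within the scatter of compound 3, so the chlorophenyl part alone gives no reason to expect a shift. As far as these compounds go, the added cyclobutyl ring is untested. For compound 4 the expected step is a 1.5-fold lower number from compound 3 to compound 4 (0.16 log units; within the scatter), not beyond the scatter. Compound 4 is estimated at 130 nM, between 40 nM and 420 nM.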

Compound 4, half-maximal inhibitory concentration: 8200 nM
Estimate against measurement, compound 4: 63-fold (1.80 log units) below, and the stated range ends below it.
By their numbers in this assay, from the lowest: compounds 1, 2 and 3 (each within the scatter of the next, the first and the last beyond it); then compound 4.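

In this assay, the substituent on a nitrogen on an aromatic ring proves sensitive to this change: 1-(3-chlorophenyl)cyclobutyl in place of (4-chloropyridin-2-yl)methyl costs much of the binding inhibition (a 43-fold higher number from compound 3 to compound 4 (1.64 log units; beyond the scatter)). On this core, therefore, one chlorinated aromatic group cannot be assumed to stand in for another. No available evidence bears on the reason for this loss.

As far as these compounds go, the change alters the aromatic ring and adds the cyclobutyl ring together, so the contribution of each remains open. A (3-chlorophenyl)methyl group on this core, or a cyclopropyl ring in place of the cyclobutyl, would help separate them.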